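Sulfamoyl-anilino series: hydroxypropyl on the sulfonamide nitrogen

The compounds below may be only part of what the source reports. "The series", "measured", "known", "first", "only" and "open" are said of these compounds alone.

Measured compounds:
compound 1 `CC[C@@H]1C(=O)N(C)c2cnc(Nc3ccc(S(=O)(=O)NCCCO)cc3)nc2N1C1CCCC1`: 331 nM
compound 2 `CC[C@@H]1C(=O)N(C)c2cnc(Nc3ccc(S(N)(=O)=O)cc3)nc2N1C1CCCC1`: 470 nM
compound 3 `CCC1C(=O)N(C)c2cnc(Nc3ccc(S(N)(=O)=O)cc3)nc2N1c1ccn(C)n1`: "not active" (no number reported)

All numbers come from a functional assay on K562 cells (Homo sapiens) for antiproliferative activity, read by CCK-8 assay, with a stated time of 72 h; on this read-out lower numbers stand for stronger inhibition of growth and higher numbers for weaker inhibition of growth. Compound 2 gives 470 nM and compound 1 gives 331 nM; the two share a core and differ only by 3-hydroxypropyl in place of hydrogen on a sulfonamide nitrogen, and the step of a 1.4-fold lower number from compound 2 to compound 1 (0.15 log units; within the scatter) is within the scatter, so the two values are not told apart here.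

Compound 3 carries a different core; how it differs from the core of compound 2 is not broken down here. In this assay compound 3 is reported as "not active" (no number reported), with no number.

Compound 4 `CCC1C(=O)N(C)c2cnc(Nc3ccc(S(=O)(=O)NCCCO)cc3)nc2N1c1ccn(C)n1` is not yet measured. It stands to compound 3 as compound 1 stands to compound 2: the change is 3-hydroxypropyl in place of hydrogen on a sulfonamide nitrogen, and since the place is described in the same words for both pairs, it is the same change. With the step from compound 2 to compound 1 within the scatter, no large shift is expected from this change on the core of compound 3. Compound 4 is therefore expected to stay weak in this assay, around 15000 nM, most likely between 3000 nM and 60000 nM, and a report of only a limit, as for compound 3, is the more probable outcome.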

Compound 4, concentration for 50% growth inhibition: 13400 nM
Beside the measured number, compound 4's estimate is 1.1-fold (0.05 log units) above it; the measured number falls inside the stated range.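

Going by these compounds alone, compound 3 carries no number and compound 4 gives 13400 nM in this assay, so no step between compound 3 and compound 4 can be read. Left open is how far 3-hydroxypropyl in place of hydrogen on a sulfonamide nitrogen shifts the read-out on the core of compound 3. No measurement shown here bears on this result.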